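A few compounds are considered here, and "the series" means these few. Any claim that something is new, unique, unknown or untested is made for them only; others in the source may bear on it.

Compound 2, with structure `Cc1ccc(-c2cccc(CNc3ccc(OCC(=O)O)c(F)c3)c2)c(Cl)c1`, stands at the lower of the two numbers recorded in a functional assay on CHO cells for agonist activity at Free fatty acid receptor 1 (Homo sapiens), read by FLIPR and calcium flux; on this read-out lower numbers stand for an effect already at smaller amounts and higher numbers for an effect only at larger amounts of compound: in this assay compound 2 gives 22.5 nM. Its nearest neighbour is compound 1, with structure `CC(C)c1ccccc1-c1cccc(CNc2ccc(OCC(=O)O)c(F)c2)c1`, which in this assay gives 86.2 nM; the step between them, a 3.8-fold lower number from compound 1 to compound 2 (0.58 log units; beyond the scatter), came from putting 2-chloro-4-methylphenyl in place of 2-isopropylphenyl on an aromatic carbon of the shared core.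

Compound 3, with structure `Cc1noc(C)c1-c1cccc(CNc2ccc(OCC(=O)O)c(F)c2)c1`, is not yet measured. It differs from compound 2 as follows: 3,5-dimethyl-1,2-oxazol-4-yl in place of 2-chloro-4-methylphenyl on an aromatic carbon. For the measured compounds named here, the only measured step, a 3.8-fold lower number from compound 1 to compound 2 (0.58 log units; beyond the scatter), shows that the group on that aromatic carbon does move the number, but both compounds in that step carry a six-membered aromatic ring of carbon only, so it says little about exchanging that ring for 3,5-dimethyl-1,2-oxazol-4-yl. With nothing closer to lean on, compound 3 is expected to land somewhat above compound 2, a step of a 2.7-fold higher number from compound 2 to compound 3 (0.43 log units; beyond the scatter) in this assay, with wide uncertainty. Compound 3 is therefore estimated at 60 nM, within a range from 20 nM to 200 nM.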

Compound 3, half-maximal effective concentration: 225 nM
Compound 3: the middle estimate sits 3.8-fold (0.57 log units) below what was measured; measured number above the stated range.
By their numbers in this assay, from the lowest: compound 2; then compound 1; then compound 3.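

Both compounds carrying a six-membered aromatic ring of carbon only give lower numbers in this assay than compound 3, so this position also responds to the kind of ring and not only to the groups on a carbon ring: the change gives a 10-fold higher number from compound 2 to compound 3 (1.00 log units; beyond the scatter) and, from the other carbon-ring compound, a 2.6-fold higher number from compound 1 to compound 3 (0.42 log units; beyond the scatter). The size of the step depends on which carbon ring is left behind, and among these three compounds the one with 3,5-dimethyl-1,2-oxazol-4-yl gives the highest number, with no compound going against that order. The change alters ring size, brings in hetero atoms and adds hydrogen-bond acceptors all at once, and no measurement available here explains the loss or separates these contributions.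

The compounds shown leave open whether the ring size or the hetero atoms carry the step, which a pyridine ring or a 3,5-dimethylphenyl group at the same carbon could begin to separate. They also leave open how a 3-methyl-1,2-oxazol-4-yl group, with one methyl fewer, would compare, and all three compounds keep the same fluorine and carboxylic acid on the shared core.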